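Aryl swap on the shared core of compound 2

The source may hold more compounds than are shown below. What is called first, only, known or untested is meant among the compounds shown, and "the series" means these compounds.

Among the compounds with values here, compound 2 `CN1CCN(CCCOc2cccc3nc(Nc4ccc(F)c(F)c4)ccc23)CC1` gives 960 nM in a functional assay on HCT-15 cells (Homo sapiens) for inhibition, read by sulforhodamine B assay, with a stated time of 48 h (on this read-out lower numbers stand for stronger inhibition of growth and higher numbers for weaker inhibition of growth), the lowest of the two numbers known, with compound 1 `CC(C)c1ccc(Nc2ccc3c(OCCCN4CCN(C)CC4)cccc3n2)cc1` at 1940 nM. Within the data shown here, the one measured step, a 2.0-fold lower number from compound 1 to compound 2 (0.31 log units; beyond the scatter), shows that changing the aryl group on this nitrogen moves the number only modestly. Compound 3 `CN1CCN(CCCOc2cccc3nc(Nc4cccc(Cl)c4)ccc23)CC1` carries 3-chlorophenyl in place of 3,4-difluorophenyl on a nitrogen on an aromatic ring, a change of the same kind, so a shift of similar or smaller size, in either direction, is expected. Compound 3 is estimated at 1200 nM, within 400 nM to 3500 nM, corresponding to an expected 1.3-fold higher number from compound 2 to compound 3 (0.10 log units; within the scatter).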

Compound 3, concentration for 50% growth inhibition: 1580 nM
The estimate for compound 3 lay 1.3-fold (0.12 log units) below the measured number, within the range that was stated.
By their numbers in this assay, from the lowest: compounds 2, 3 and 1 (each within the scatter of the next, the first and the last beyond it).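

In this assay, the 3-chlorophenyl group of compound 3 stays within the scatter of both other aryl groups on this nitrogen: a 1.6-fold higher number from compound 2 to compound 3 (0.22 log units; within the scatter), and a 1.2-fold lower number from compound 1 to compound 3 (0.09 log units; within the scatter). Within the data shown here, the single step beyond the scatter, between compound 1 and compound 2, therefore has an intermediate neighbour that cannot be separated from either end. Exchanging 3,4-difluorophenyl for 3-chlorophenyl yields no readable change here.

As far as these compounds go, whether a pyridyl ring, a cyclohexyl group or an aryl ring bearing a carboxylic acid on this nitrogen would leave this narrow band remains open. No measurement bears on why these three aryl groups read so closely.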